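A Smaller Ester Arm on a Sulfonamide Core

The source may report more compounds than this note shows. Statements on the series, on what has been measured and on what is new or still open speak of the compounds shown alone.

Compound 1 `COc1ccccc1-c1ccc(S(=O)(=O)N2CCC(N3CCC(C)CC3)CC2)cc1` and compound 2 `Cc1cc(C)c(S(=O)(=O)N2CCC(N3CCC(CCC#N)CC3)CC2)c(C)c1` share a sulfonamide-linked core and were both examined in an ADME assay on HCT-116 cells (Homo sapiens) for cytotoxicity, read by CellTiter-Glo, with a stated time of 72 h; a higher number here means a weaker inhibitor, a lower number a stronger inhibitor. In this assay compound 1 gives > 5000 nM, which is a limit of the assay rather than a number. Compound 2 in this assay likewise gives > 5000 nM, again a limit. Both compounds therefore sit at the limit of > 5000 nM in this assay, at which 2 of the 2 values shown sit, so compound 1 stands among the weak inhibitors here, with no number that would rank it against compound 2. Compound 3 `COC(=O)c1ccc(S(=O)(=O)N2CCC(N3CCC(C)CC3)CC2)cc1` has not yet been measured in this assay. It differs from compound 1 in one place: methoxycarbonyl in place of 2-methoxyphenyl on an aromatic carbon. For the measured compounds named here, with no measured step between any two compounds to guide the size of the change, compound 3 is expected to stay weak, and the step that the limit leaves unreadable from compound 1 to compound 3 is expected to be none beyond the scatter. Compound 3 is estimated at 8000 nM, with a range from 3000 nM to 30000 nM.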

Compound 3, half-maximal inhibitory concentration: > 5000 nM
Compound 3 was reported as a limit; the forecaster's own chance of this, stated with the estimate: 80%; the middle value is on the limit's open side.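

In this assay, for the compounds shown here, compound 3 gives > 5000 nM as a limit of the assay and not a number, and with compound 1 also at a limit, no step between the two can be read. The compounds shown leave open how far apart they lie, and which change on the shared core would give a readable number in this assay at all.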